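Amide-side variation on the shared core: benzyl replacement

A few compounds are considered here, and "the series" means these few. Any claim that something is new, unique, unknown or untested is made for them only; others in the source may bear on it.

Compound 1 `O=C(COc1ccc2cc(C(O)(C(F)(F)F)C(F)(F)F)c(O)cc2c1)Nc1nc2ccccc2s1` carries a 1,3-benzothiazol-2-yl group on the amide-type nitrogen and, in an assay on isolated protein for inhibition of tyrosine-protein phosphatase non-receptor type 13 (Homo sapiens), read by spectrophotometry (on this read-out higher numbers stand for weaker inhibition and lower numbers for stronger inhibition), compound 1 gives 9900 nM, the lowest of the three numbers recorded so far. Compound 3 `Cc1ccc(S(=O)(=O)NNC(=O)COc2ccc3cc(C(O)(C(F)(F)F)C(F)(F)F)c(O)cc3c2)cc1` differs from compound 1 only at that nitrogen; in this assay compound 3 gives 14900 nM, and the step of a 1.5-fold higher number from compound 1 to compound 3 (0.18 log units; within the scatter) lies within the scatter. For the measured compounds named here, compound 2 `Oc1c(-c2ccccc2)cccc1C(O)(C(F)(F)F)C(F)(F)F`, which lacks the whole amide arm, gives 449000 nM in this assay, a far higher number than compound 1; no single-point step connects these two.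

Compound 4 `O=C(COc1ccc2cc(C(O)(C(F)(F)F)C(F)(F)F)c(O)cc2c1)NCc1ccccc1` is not yet measured. It differs from compound 1 by benzyl in place of 1,3-benzothiazol-2-yl on an amide-type nitrogen. Going by the values given here, the only measured step that bears on this position is the one from compound 1 to compound 3, which exchanged the same group for one of a quite different kind without moving the number beyond the scatter. On that basis a similarly small step is expected here, a 1.4-fold higher number from compound 1 to compound 4 (0.15 log units; within the scatter), with no direction beyond the scatter called for. Compound 4 is therefore estimated at 14000 nM in this assay, with a range from 5000 nM to 45000 nM.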

Compound 4, half-maximal inhibitory concentration: > 20000 nM
Compound 4: only a limit was reported; the forecaster's own chance of this, stated with the estimate: 10%; middle value at least 1.4-fold (0.15 log units) away from the limit.
By their numbers in this assay, from the lowest: compounds 1 and 3 (each within the scatter of the next); then compound 2.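

Compound 4 gives a limit rather than a number in this assay: the limit of > 20000 nM in this assay, at which 1 of the 4 values shown sits. For the compounds shown here, this is the first compound with the amide arm of compound 1 to reach such a limit, so the group on this amide-type nitrogen can no longer be described only by values that sit within the scatter of each other. Read as floors, an at least 2.0-fold higher number from compound 1 to compound 4 (0.30 log units; that floor lies within the scatter) and an at least 1.3-fold higher number from compound 3 to compound 4 (0.12 log units; that floor lies within the scatter) both point the same way, and benzyl, with 0 hydrogen-bond acceptors against 2 on the 1,3-benzothiazol-2-yl group, gives no sign yet of matching either earlier group at this nitrogen.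

Both floors lie within the scatter, so the compounds shown do not settle whether compound 4 truly departs from compound 1 or compound 3, nor how far, and the part played by the acceptors counted on the leaving group stays unresolved. Also open, as far as these compounds go, is how a cyclohexylmethyl group, a phenyl ring attached directly to this nitrogen, or a longer chain carrying a carboxylic acid or an amine would read here.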